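The source may report more compounds than this note shows. Statements on the series, on what has been measured and on what is new or still open speak of the compounds shown alone.

Three compounds share one core and differ only in the methoxy-bearing ring that sits on a double-bonded chain carbon. Compound 1 `COc1ccc(/C=C/C(=O)c2ccc(OCCn3cc(CN4C(=O)/C=C/C(C)(C)C/C=C(\C)CC/C=C/4C)nn3)cc2O)cc1` gives 2.06 ug/mL in a functional assay on HepG2 cells (Homo sapiens) for antiproliferative activity; a lower number here means a stronger inhibitor, a higher number a weaker inhibitor. Compound 2 `COc1cccc(/C=C/C(=O)c2ccc(OCCn3cc(CN4C(=O)/C=C/C(C)(C)C/C=C(\C)CC/C=C/4C)nn3)cc2O)c1` gives 1.01 ug/mL in this assay, and compound 3 `COc1ccccc1/C=C/C(=O)c1ccc(OCCn2cc(CN3C(=O)/C=C/C(C)(C)C/C=C(\C)CC/C=C/3C)nn2)cc1O` gives 1.71 ug/mL in this assay. Compound 3 thus stands second highest of the three numbers, with compound 1 nearest and compound 2 furthest: the step of a 1.2-fold lower number from compound 1 to compound 3 (0.08 log units; within the scatter) and the step of a 1.7-fold higher number from compound 2 to compound 3 (0.23 log units; within the scatter) both lie within the scatter, whereas the step of a 2.0-fold lower number from compound 1 to compound 2 (0.31 log units; beyond the scatter) is a modest change beyond it. Compound 4 `COc1cc(/C=C/C(=O)c2ccc(OCCn3cc(CN4C(=O)/C=C/C(C)(C)C/C=C(\C)CC/C=C/4C)nn3)cc2O)cc(OC)c1OC` is not yet measured; it differs from compound 3 by 3,4,5-trimethoxyphenyl in place of 2-methoxyphenyl on a double-bonded chain carbon bound to a double-bonded chain carbon. Within the data shown here, no measured step adds methoxy groups, so only the three swaps of a single methoxy position inform the expectation, and none of them gave more than a modest step. A small step is therefore expected in this assay, a 1.1-fold lower number from compound 3 to compound 4 (0.06 log units; within the scatter), most likely not beyond the scatter. Compound 4 is estimated at 1.5 ug/mL, with a range from 0.7 ug/mL to 3.5 ug/mL.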

Compound 4, half-maximal inhibitory concentration: 1.44 ug/mL
Compound 4: the middle estimate sits 1.0-fold (0.02 log units) above what was measured, within the range that was stated.
By their numbers in this assay, from the lowest: compounds 2, 4, 3 and 1 (each within the scatter of the next, the first and the last beyond it).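

The position accepts much more than a single methoxy group: in this assay, 3,4,5-trimethoxyphenyl adds heavy atoms to the group and takes it from 1 hydrogen-bond acceptor to 3, yet the three comparisons give a 1.2-fold lower number from compound 3 to compound 4 (0.07 log units; within the scatter), a 1.4-fold higher number from compound 2 to compound 4 (0.15 log units; within the scatter) and a 1.4-fold lower number from compound 1 to compound 4 (0.16 log units; within the scatter). Compound 4 therefore cannot be told apart from any of the compounds with a single methoxy group, so this larger group brings no clear gain or loss in this cell assay. Nothing available here accounts for this flat result.

From the compounds shown here alone, all four rings carry only methoxy groups, so the effect of a plain phenyl ring, or of a ring bearing an amine or a carboxylic acid, remains open. A single cell line also leaves open whether the same flat result would appear in other cells.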